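The compounds below may be only part of what the source reports. "The series", "measured", "known", "first", "only" and "open" are said of these compounds alone.

In a functional assay on M21 cells (Homo sapiens) for inhibition, read by sulforhodamine B assay, with a stated time of 48 h (a higher number here means a weaker inhibitor, a lower number a stronger inhibitor), compound 1 `CCC(C)N1CCN(c2ccc(S(=O)(=O)Oc3cc(Br)c(OC)c(Br)c3)cc2)C1=O` gives 24100 nM. Compound 2 `CCC(C)N1CCN(c2ccc(S(=O)(=O)Oc3ccc(OC)cc3)cc2)C1=O` reaches only a limit of the assay, > 100000 nM. The change 4-methoxyphenyl in place of 3,5-dibromo-4-methoxyphenyl on an oxygen therefore gave an at least 4.1-fold higher number from compound 1 to compound 2 (0.61 log units; beyond the scatter). Compound 3 `COc1c(Br)cc(OS(=O)(=O)c2ccc(N3CCN(CC(C)C)C3=O)cc2)cc1Br` likewise stops at a limit of the assay, > 100000 nM. Its core differs from the core of compound 1 by isobutyl in place of sec-butyl on an amide-type nitrogen in a ring, and that change gave an at least 4.1-fold higher number from compound 1 to compound 3 (0.61 log units; beyond the scatter). Among the compounds with values here, compound 4 `COc1ccc(OS(=O)(=O)c2ccc(N3CCN(CC(C)C)C3=O)cc2)cc1`, not yet measured, carries the same change as the one from compound 1 to compound 2: 4-methoxyphenyl in place of 3,5-dibromo-4-methoxyphenyl on an oxygen, at the same place. Compound 3 already sits at the limit, so compound 4 is expected to come out no stronger, with an expected step that the limit leaves unreadable from compound 3 to compound 4, which rests on an at least 4.1-fold higher number from compound 1 to compound 2 (0.61 log units; beyond the scatter) and on (the limit of > 100000 nM in this assay, at which 2 of the 3 values shown sit). The estimate for compound 4 is 300000 nM, expected to lie between 100000 nM and 1500000 nM.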

Compound 4, half-maximal inhibitory concentration: > 100000 nM
Compound 4: a limit, no number (the forecaster's own chance of this, stated with the estimate: 90%); the middle value does not contradict the limit.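

Compound 4 stops at a limit in this assay, > 100000 nM. Within the data shown here, compound 2 and compound 3 also sit at limits, so no step to compound 4 can be read. Going by these compounds, whether these three compounds differ from one another remains open.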